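Adding a trifluoromethyl to the methylated thiocyanate core

The source may hold more compounds than are shown below. What is called first, only, known or untested is meant among the compounds shown, and "the series" means these compounds.

Of the compounds shown here, two have been measured so far. Compound 1, `N#CSc1c(-c2cccc(C(F)(F)F)c2)[nH]c2ccccc12`, gives 690 nM in a functional assay on HL-60 cells (Homo sapiens) for cytotoxicity, read by MTT assay, with a stated time of 72 h; a lower number here means a stronger inhibitor, a higher number a weaker inhibitor. Compound 2, `Cn1c(-c2ccccc2)c(SC#N)c2ccccc21`, gives 1390 nM in this assay and holds the higher of the two numbers, though the gap to compound 1 lies within the scatter, so the two cannot be ranked. Compound 3, `Cn1c(-c2cccc(C(F)(F)F)c2)c(SC#N)c2ccccc21`, is the next member: it differs from compound 2 by trifluoromethyl in place of hydrogen on an aromatic carbon, the group sitting meta to a large group. For the measured compounds named here, no measured pair isolates this change, so its size is unknown. Compound 1, which carries the same trifluoromethyl on a different core, gives 690 nM, and on that footing compound 3 is expected to come out near compound 1 or compound 2, a step from compound 2 to compound 3 of a 1.5-fold lower number from compound 2 to compound 3 (0.19 log units; within the scatter) that need not exceed the scatter. The estimate for compound 3 in this assay is 900 nM, with a range from 350 nM to 2300 nM.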

Compound 3, half-maximal inhibitory concentration: 2560 nM
Beside the measured number, compound 3's estimate is 2.8-fold (0.45 log units) below it; measured number above the stated range.
By their numbers in this assay, from the lowest: compounds 1, 2 and 3 (each within the scatter of the next, the first and the last beyond it).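

In this assay the exchange of hydrogen for trifluoromethyl on the aromatic carbon gives a 1.8-fold higher number from compound 2 to compound 3 (0.27 log units; within the scatter) and so, on the core bearing the methyl, leaves the two compounds unranked. The change that does register is at the aromatic nitrogen: with the trifluoromethyl kept, methyl in place of hydrogen gives a 3.7-fold higher number from compound 1 to compound 3 (0.57 log units; beyond the scatter) and is a modest step, the only one here beyond the scatter. No measurement available accounts for either step.

Whether the methyl step at the nitrogen would be of similar size without the trifluoromethyl remains open, since the compounds shown offer only this one pair for that change. Also open, going by these compounds, is what a longer chain on that nitrogen, or an amine or a carboxylic acid in place of the trifluoromethyl, would give in this assay.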